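Restoring an aromatic ring on the amide carbonyl

This account rests on a few compounds, and the source may have more. Where it says the series, first, only, none or still open, it means among the compounds named here.

In a functional assay on HUVEC cells (Homo sapiens) for inhibition, tested at 10 ug/mL (a lower number here means a weaker effect, a higher number a stronger effect of the compound at the concentration tested), compound 3 `COC(=O)C(=O)Nc1cccc(C(=O)/C=C/c2ccc(O)c(OC)c2)c1` gives 43%, the lowest of the three numbers recorded. Its nearest neighbour is compound 2 `COc1cc(/C=C/C(=O)c2cccc(NC(=O)c3cccs3)c2)ccc1O`, which gives 90%, and the furthest is compound 1 `COc1cc(/C=C/C(=O)c2cccc(NC(=O)c3c(Cl)cccc3Cl)c2)ccc1O`, which gives 99%. Both compounds carry an aromatic ring on the carbonyl carbon where compound 3 carries methoxycarbonyl, and the shifts were a number 56 percentage points lower from compound 1 to compound 3 (beyond the scatter) and a number 47 percentage points lower from compound 2 to compound 3 (beyond the scatter), while the two aromatic rings differed from each other only by a number 9 percentage points lower from compound 1 to compound 2 (within the scatter).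

Compound 4 `COc1cc(/C=C/C(=O)c2cccc(NC(=O)c3ccccc3)c2)ccc1O` turns this around: phenyl in place of methoxycarbonyl on a carbonyl carbon. The change runs in the opposite direction to the two large drops, putting an aromatic ring back where compound 1 and compound 2 also carry one. A large rise is therefore expected, roughly undoing the step from compound 2 to compound 3, so that compound 4 is expected to land near the two ring-bearing compounds. The estimated step is a number 45 percentage points higher from compound 3 to compound 4 (beyond the scatter), and compound 4 is expected to give about 88%, within a range from 70% to 99%.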

Compound 4, a percentage reported as inhibition, at one concentration (the size of the read-out at that concentration, not a potency): 69%
Beside the measured number, compound 4's estimate is 19 percentage points above it; measured number below the stated range.
By their numbers in this assay, from the lowest: compound 3; then compound 4; then compounds 2 and 1 (each within the scatter of the next).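

In this assay the change to phenyl gives a number 26 percentage points higher from compound 3 to compound 4 (beyond the scatter) and is modest, so an aromatic ring on this carbonyl carbon does not by itself reach the level of the other two ring-bearing compounds. The choice of ring also counts, which compound 1 and compound 2 alone could not show, since they lie within the scatter of each other: the step is a number 21 percentage points lower from compound 2 to compound 4 (beyond the scatter) for thiophen-2-yl replaced by phenyl and a number 30 percentage points lower from compound 1 to compound 4 (beyond the scatter) for 2,6-dichlorophenyl replaced by phenyl. This position therefore separates one aromatic ring from another, as well as rings from methoxycarbonyl.

Nothing available gives a reason for the gap between phenyl and the other two rings. On these data alone, whether a phenyl carrying a single chlorine, a furan or a pyridine ring would stay at the level of phenyl or rise toward the other two rings remains open.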